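Azidomethyl to hex-1-yn-1-yl on the nucleoside of compound 3

A few compounds are considered here, and "the series" means these few. Any claim that something is new, unique, unknown or untested is made for them only; others in the source may bear on it.

Three compounds of different make-up have been run in an ADME assay on L1210/0 cells (Mus musculus) for cytotoxicity, with a stated time of 48 h; a higher number here means a weaker inhibitor, a lower number a stronger inhibitor. Compound 1 `Cc1ccc(C(=O)/C=C/c2cc(O)nc(O)n2)cc1` gives 182000 nM. Compound 2 `COC1=C(OC)/C(=C/Cn2cnc3c(Cl)ncnc32)OC1=O` gives 14000 nM and carries the lowest number of the three. Compound 3 `[N-]=[N+]=NCc1cn([C@H]2C[C@H](O)[C@@H](CO)O2)c(=O)[nH]c1=O` gives 124000 nM; that number is the second highest of the three. The values of compound 3 and compound 1 sit within the scatter of each other, so no order between them is claimed. The gap from compound 3 to compound 2 lies beyond the scatter, with compound 2 the lower of the two.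

Compound 4 `CCCCC#Cc1cn([C@H]2C[C@H](O)[C@@H](CO)O2)c(=O)[nH]c1=O` keeps the sugar and the core of compound 3 and changes only one substituent: hex-1-yn-1-yl in place of azidomethyl on an aromatic carbon. Among the measured compounds shown here, no pair of compounds differing in one place has yet been measured, so no step is on record to lean on. On the three numbers alone, a modest step toward a lower number in this assay is expected for compound 4, of a size close to the scatter and possibly within it.

The expected step from a 2.1-fold lower number from compound 3 to compound 4 (0.32 log units; beyond the scatter) places compound 4 at an estimated 60000 nM, with a likely range from 15000 nM to 250000 nM.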

Compound 4, half-maximal inhibitory concentration: > 200000 nM
Compound 4 was reported as a limit; the forecaster's own chance of this, stated with the estimate: 10%; middle value at least 3.3-fold (0.52 log units) from the limit.
By their numbers in this assay, from the lowest: compound 2; then compounds 3 and 1 (each within the scatter of the next). At a limit, above all of these: compound 4.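

In this assay compound 4 gives > 200000 nM, which is a limit of the assay and not a number. Among the compounds shown here, this is the only one-place comparison: with the sugar and the core held constant, hex-1-yn-1-yl in place of azidomethyl on the aromatic carbon, two atoms from the ring nitrogen, gives an at least 1.6-fold higher number from compound 3 to compound 4 (0.20 log units; that floor lies within the scatter), so the change does not move this position toward a lower number in this assay. The step has a floor but no measured top, and that floor alone does not carry it beyond the scatter: the limit of > 200000 nM in this assay, at which 1 of the 4 values shown sits.

On these data alone, the true size of the step stays open, and a single pair cannot separate the effect of losing azidomethyl from that of bringing in the triple bond or the six-carbon chain. A short chain such as ethynyl or propyl, or an aminomethyl group or a carboxylic acid on the same aromatic carbon, would show whether any substituent at this position gives a number clearly different from that of compound 3.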